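This account rests on a few compounds, and the source may have more. Where it says the series, first, only, none or still open, it means among the compounds named here.

Compound 1 `C#CCOc1ccc(/C=C/C(=O)c2ccc(OC)cc2)cc1` and compound 2 `C#CCOc1ccc(/C=C/C(=O)c2ccc([N+](=O)[O-])cc2)cc1` differ in one place on the shared core. Among the compounds with values here, in a functional assay on MCF7 cells (Homo sapiens) for inhibition, read by MTT assay, with a stated time of 48 h, tested at 10 uM (a lower number here means less inhibition of growth, a higher number more inhibition of growth at the concentration tested), compound 1 gives 32%, and compound 2 gives 44%, so that a number 12 percentage points higher from compound 1 to compound 2 (beyond the scatter) is the only single-site step among the measured compounds. Compound 3 `O=C(/C=C/c1ccc(OCc2cn(Cc3ccccc3Br)nn2)cc1)c1ccc(Br)cc1` carries a longer arm on the other side of the core; in this assay compound 3 gives 44%, the same digits as compound 2, and both stand above compound 1 by a gap beyond the scatter.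

Compound 4 `O=C(/C=C/c1ccc(OCc2cn(Cc3cccc(F)c3)nn2)cc1)c1ccc(Br)cc1` is reached from compound 3 by one change: 3-fluorophenyl in place of 2-bromophenyl on a saturated chain carbon bound to an aromatic nitrogen. Within the data shown here, no measured step touches this arm of the molecule; the one step known, a number 12 percentage points higher from compound 1 to compound 2 (beyond the scatter), concerns a different place on the core and was modest in size, so it gives no direct guide to the exchange of one halogenated phenyl for another. On that basis the expected change in this assay from compound 3 to compound 4 is none beyond the scatter, that is a number 2 percentage points lower from compound 3 to compound 4 (within the scatter). Compound 4 is therefore estimated to give 42% in this assay, with a range from 25% to 60%.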

Compound 4, percent growth inhibition at one concentration: 42%
Compound 4: the middle estimate sits on the measured number at the digits printed; the measured number falls inside the stated range.
By their numbers in this assay, from the lowest: compounds 1, 4, 2 and 3 (each within the scatter of the next, the first and the last beyond it).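

In this assay, within the data shown here, this is the first look at the arm on the saturated chain carbon bound to an aromatic nitrogen, and exchanging 2-bromobenzyl for 3-fluorobenzyl gives a number 2 percentage points lower from compound 3 to compound 4 (within the scatter), so this arm can carry either halogenated benzyl group with no difference that can be read at the concentration tested. The single-site step known before concerned a different place on the shared core and stood beyond the scatter, whereas this exchange, with the same count of heavy atoms entering and leaving, does not. Since the halogen and its printed location on the phenyl differ together in this one step, and nothing shown gives a reason for the result, the pair neither separates those two features nor explains why the numbers stay so close.

The compounds shown leave open whether this arm would read the same with a plain benzyl group, or with an amine or a carboxylic acid on the phenyl. They also leave open whether a longer chain between the aromatic nitrogen and the phenyl would shift the number, and whether nitro on the far aromatic ring would do so in the presence of this arm.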